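Methylating the chain hydroxyl of a dienone phenol

The source may report more compounds than this note shows. Statements on the series, on what has been measured and on what is new or still open speak of the compounds shown alone.

Measured compounds:
Compound 1, `COCCCN1C(/C=C/c2ccc(O)cc2)=CC(=O)CC1c1ccc(O)cc1`, gives 91.7%.
Compound 2, `O=C(/C=C(/C=C/c1ccc(O)cc1)NCCCO)/C=C/c1ccc(O)cc1`, gives 80.5%.
Compound 3, `COc1cc(/C=C/C(=O)/C=C(/C=C/c2ccc(O)c(OC)c2)NCCCO)ccc1O`, gives 89.9%.

These three readings come from an ADME assay on CHO-K1 cells (Cricetulus griseus) for activation, read by fluorescence, tested at 10 uM; on this read-out higher numbers stand for a weaker effect at the one concentration tested and lower numbers for a stronger effect. Among them compound 2 carries the lowest number. The reading for compound 3 sits within the usual scatter of it, so the two cannot be told apart; the reading for compound 1 lies beyond the scatter, so that gap is real.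

The new member is compound 4, `COCCCNC(=C\C(=O)/C=C/c1ccc(O)cc1)/C=C/c1ccc(O)cc1`. It differs from compound 2 in one place: methyl in place of hydrogen on an oxygen on a saturated carbon. Everything else in the two structures is the same.

Among the compounds with values here, no pair of measured compounds differs in exactly this one place, so no measured step can be borrowed. The change is a single carbon added on an oxygen at the end of a chain, and in this assay such a small alteration is expected to move the number little, with no clear direction and most likely staying within the scatter. Compound 4 is therefore expected to read close to compound 2, around 84%, between 72% and 96%, which means an expected step of a number 3.5 percentage points higher from compound 2 to compound 4 (within the scatter).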

Compound 4, a percentage reported as activity, at one concentration (the size of the read-out at that concentration, not a potency): 97%
Estimate against measurement, compound 4: 13 percentage points below; measured number outside the range, above it.
By their numbers in this assay, from the lowest: compounds 2, 3, 1 and 4 (each within the scatter of the next, the first and the last beyond it).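

In this assay, within the data shown here, changing hydroxy to methoxy at the end of the chain gives a number 16.5 percentage points higher from compound 2 to compound 4 (beyond the scatter), the first step in this set that isolates a single change. It shows that this chain end is not a silent position: one methyl on that oxygen, with the rest of the structure untouched, is enough to weaken the effect seen at the one concentration tested. Nothing measured here explains this shift.

As far as these compounds go, this is one pair on one core, so it remains open whether the same change would act in the same way on the core of compound 3. From the compounds shown here alone, it also remains open how an amine or a carboxylic acid at the chain end, or a longer chain still ending in hydroxy, would read.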